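Growth inhibition notes: methoxy in place of chloro

The source may report more compounds than this note shows. Statements on the series, on what has been measured and on what is new or still open speak of the compounds shown alone.

In a functional assay on T47D cells (Homo sapiens) for inhibition, read by CCK-8 assay, with a stated time of 72 h, tested at 10 uM (a lower number here means less inhibition of growth, a higher number more inhibition of growth at the concentration tested), compound 1 (`CN(C)C(=O)c1cc2cnc(Nc3ccc(N)cn3)nc2n1C1CCCC1`) gives 61.1% and compound 2 (`CN(C)C(=O)c1cc2cnc(Nc3ccc(NC(=O)C4(C(=O)Nc5ccc(Cl)cc5)CC4)cc3)nc2n1C1CCCC1`) gives 95% as the higher of the two numbers, beyond the scatter. Compound 3 (`COc1ccc(NC(=O)C2(C(=O)Nc3ccc(Nc4ncc5cc(C(=O)N(C)C)n(C6CCCC6)c5n4)cc3)CC2)cc1`) has methoxy in place of chloro on an aromatic carbon, para to a large group (methoxy in place of chloro on an aromatic carbon). Among the measured compounds shown here, no measured pair shows this change, so there is no direct precedent for its size. A small fall in this assay is expected, possibly none beyond the scatter. The estimated move is a number 5 percentage points lower from compound 2 to compound 3 (within the scatter) in size. For compound 3 the expected value is 90% within a range of 78% to 98% at the concentration tested.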

Compound 3, percent growth inhibition at one concentration: 96.1%
Estimate against measurement, compound 3: 6.1 percentage points below, and the stated range covers the measured number.
By their numbers in this assay, from the lowest: compound 1; then compounds 2 and 3 (each within the scatter of the next).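

In this assay, the step is a number 1.1 percentage points higher from compound 2 to compound 3 (within the scatter), so at this aromatic carbon, para to a large group, methoxy and chloro cannot be told apart. The 4-methoxyphenyl group, with its extra heavy atom and hydrogen-bond acceptor, therefore keeps the growth inhibition seen with the 4-chlorophenyl group at the concentration tested. Nothing available bears on why the two groups read alike.

Going by these compounds, whether an amine or a carboxylic acid at this position would do the same remains open. On these data alone, with one concentration as the only read-out, any potency difference between compound 2 and compound 3 also remains open.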